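Moving the methoxy group on the aniline ring

The compounds below may be only part of what the source reports. "The series", "measured", "known", "first", "only" and "open" are said of these compounds alone.

Values in a functional assay on MCF7 cells (Homo sapiens) for inhibition, read by sulforhodamine B assay; a lower number here means a stronger inhibitor, a higher number a weaker inhibitor:
- Compound 1 `O=C1C=C(Nc2ccccc2F)C(=O)c2c1nc1n2[C@H]2OC[C@@H](O)[C@H]2OC1`: 3640 nM
- Compound 2 `COc1ccccc1NC1=CC(=O)c2nc3n(c2C1=O)[C@H]1OC[C@@H](O)[C@H]1OC3`: > 4000 nM (a limit of the assay, not a number)

Compound 2 has no exact number, and its > 4000 nM is a limit. It stands at the limit of > 4000 nM in this assay, at which 1 of the 2 values shown sits.

Compound 3 `COc1ccc(NC2=CC(=O)c3nc4n(c3C2=O)[C@H]2OC[C@@H](O)[C@H]2OC4)cc1` keeps the shared core and differs from compound 2 in one group: 4-methoxyphenyl in place of 2-methoxyphenyl on an amine nitrogen. In words, this is 4-methoxyphenyl in place of 2-methoxyphenyl on an amine nitrogen.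

Among the compounds with values here, only one measured step touches this group. It is an at least 1.0-fold higher number from compound 1 to compound 2 (0.04 log units; that floor lies within the scatter), and it puts methoxy in place of fluoro on an aromatic carbon. That step is a change of group, whereas compound 3 carries the same group in a different place, so no measurement covers this exact kind of change. With so little to go on, no step beyond the scatter is expected in this assay, and no direction can be given.

The expected change is a number no higher from compound 2 to compound 3 (the limit leaves the size open).

For compound 3 the estimated value is 4000 nM, with an expected range from 1800 nM to 9000 nM.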

Compound 3, half-maximal inhibitory concentration: 5420 nM
Compound 3: middle estimate off by 1.4-fold (0.13 log units), on the low side; measured number inside the range.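

In this assay, within the data shown here, compound 3 gives 5420 nM, the first exact number for a compound with a methoxyphenyl group on the amine nitrogen. Putting 4-methoxyphenyl in place of 2-fluorophenyl on that nitrogen gives a 1.5-fold higher number from compound 1 to compound 3 (0.17 log units; within the scatter), so this swap does not separate the two compounds in this measurement. Compound 2 has only a limit of the assay rather than a number, and the step that moves the methoxy group from 2-methoxyphenyl to 4-methoxyphenyl cannot be read: the limit of > 4000 nM in this assay, at which 1 of the 3 values shown sits.

On these data alone, whether the place of the methoxy group on the ring matters at all in this assay stays open, as only one of the two methoxyphenyl compounds has an exact number. Also open, as far as these compounds go, is what a quite different group on the same phenyl ring, such as a carboxylic acid or an amine, would do to this number.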